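Adding a dichlorophenyl group to a compound without a result

The source may hold more compounds than are shown below. What is called first, only, known or untested is meant among the compounds shown, and "the series" means these compounds.

Among the compounds with values here, in a functional assay on A-375 cells (Homo sapiens) for antiproliferative activity, read by trypan blue exclusion and crystal violet staining, with a stated time of 72 h (a higher number here means a weaker inhibitor, a lower number a stronger inhibitor), compound 1 (`O=C(NCc1ccc2cccnc2c1O)C1CCCCC1`) gives 910 nM and supplies the only number available here. Compound 2 (`CCCCC(=O)NCc1ccc2cccnc2c1O`) has no number to stand on, its entry reading "nd" (no result reported) in this assay with no result reported. Compound 3 (`CCCCC(=O)NC(c1cc(Cl)cc(Cl)c1)c1ccc2cccnc2c1O`) differs from compound 2 by a single change (3,5-dichlorophenyl in place of hydrogen on a saturated chain carbon bound to an amide-type nitrogen and an aromatic carbon): 3,5-dichlorophenyl in place of hydrogen on a saturated chain carbon bound to an amide-type nitrogen and an aromatic carbon. Within the data shown here, no measured step shows what such a change does, and compound 2 offers no starting value. Judged against compound 1 at 910 nM as the sole reference, a moderate gain in strength in this assay is expected, though a result within the usual scatter of that value would be no surprise. For compound 3 the estimated value is 400 nM (expected range 80 nM to 2000 nM).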

Compound 3, half-maximal inhibitory concentration: 90 nM
Compound 3: the middle estimate sits 4.4-fold (0.65 log units) above what was measured; low and high end bracket the measured number.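

No step can be read between compound 2 and compound 3, since compound 2 has no number in this assay. From the compounds shown here alone, what the 3,5-dichlorophenyl group itself does to strength in this assay stays open. No evidence bears on this result.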